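The source may report more compounds than this note shows. Statements on the series, on what has been measured and on what is new or still open speak of the compounds shown alone.

Compound 2 `Cc1cc(-c2c(F)cc3c(=O)c(Cc4cccc(O)c4O)cn(C4CC4)c3c2F)cc(C)n1` gives the lowest of the three numbers measured in a functional assay on P388 cells (Mus musculus) for cytotoxicity (a higher number here means a weaker inhibitor, a lower number a stronger inhibitor), namely 880 nM. Compound 1 `Cc1cc(-c2c(F)cc3c(=O)ccn(C4CC4)c3c2F)cc(C)n1` carries hydrogen on the aromatic carbon that in compound 2 bears the 2,3-dihydroxybenzyl group. In this assay compound 1 gives 15000 nM. Compound 3 `Cc1cc(-c2c(F)cc3c(=O)c(Cc4ccccc4N)cn(C4CC4)c3c2F)cc(C)n1`, with a 2-aminobenzyl group in that place, gives 2100 nM. The measured steps are a 17-fold lower number from compound 1 to compound 2 (1.23 log units; beyond the scatter) and a 7.1-fold lower number from compound 1 to compound 3 (0.85 log units; beyond the scatter), and between the two substituted compounds a 2.4-fold higher number from compound 2 to compound 3 (0.38 log units; beyond the scatter).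

Compound 4 `Cc1cc(-c2c(F)cc3c(=O)c(Cc4ccc(Cl)cc4)cn(C4CC4)c3c2F)cc(C)n1` has not yet been measured. It differs from compound 2 in one place: 4-chlorophenyl in place of 2,3-dihydroxyphenyl on a saturated chain carbon bound to an aromatic carbon. Going by the values given here, only one measured step bears on an exchange of this kind: from compound 2 to compound 3, which also swaps one aryl group for another on the saturated chain carbon bound to the aromatic carbon, and that step was modest. The two steps from compound 1 show that each benzyl group measured so far lowered the number by a large or modest amount. Compound 4 is therefore expected to show a modestly higher number than its parent, a 2.8-fold higher number from compound 2 to compound 4 (0.45 log units; beyond the scatter). That would leave it closer to compound 3 than to compound 2. The estimate for compound 4 in this assay is 2500 nM, with a range from 900 nM to 7000 nM.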

Compound 4, half-maximal inhibitory concentration: 20000 nM
Compound 4: middle estimate off by 8.0-fold (0.90 log units), on the low side, and the stated range ends below it.
By their numbers in this assay, from the lowest: compound 2; then compound 3; then compounds 1 and 4 (each within the scatter of the next).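

In this assay the 4-chlorobenzyl group shows that a substituted benzyl group on this aromatic carbon does not by itself lower the number: the comparison with hydrogen gives a 1.3-fold higher number from compound 1 to compound 4 (0.12 log units; within the scatter) and so cannot tell the two compounds apart. Going by these compounds alone, the aryl group on the saturated chain carbon bound to the aromatic carbon therefore matters far more than the single earlier exchange suggested, with 4-chlorophenyl in place of 2,3-dihydroxyphenyl giving a 23-fold higher number from compound 2 to compound 4 (1.36 log units; beyond the scatter) and the same group in place of 2-aminophenyl giving a 9.5-fold higher number from compound 3 to compound 4 (0.98 log units; beyond the scatter) as the second large gap in the set. The lowering seen with compound 2 and compound 3 thus goes with those particular aryl groups and not with every benzyl group placed here.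

Compound 4 changes both the kind of substituent and its place name on the ring, so a plain benzyl group, a 4-hydroxybenzyl group or a 4-aminobenzyl group would be needed to separate these two changes. Nothing available explains why these aryl groups differ so widely.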